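Fluoro for Methoxy on the Aryl Ring of Compound 1

This account rests on a few compounds, and the source may have more. Where it says the series, first, only, none or still open, it means among the compounds named here.

Compound 1 `COc1ccc(-c2cn(CC(=O)Nc3nc4ccccc4s3)nn2)cc1`: 1330 nM
Compound 2 `COC(=O)c1ccc(-c2cn(CC(=O)Nc3cc(C)on3)nn2)cc1`: > 30000 nM

Within the data shown here, in a functional assay on BMDM cells (Mus musculus, strain C57BL/6) for inhibition, with a stated time of 2 days (a lower number here means a stronger inhibitor, a higher number a weaker inhibitor), compound 1 gives 1330 nM, the only number among the values shown. Compound 2 reaches only (the limit of > 30000 nM in this assay, at which 1 of the 2 values shown sits), which is a limit of the assay and not a number. Compound 3 `O=C(Cn1cc(-c2ccc(F)cc2)nn1)Nc1nc2ccccc2s1` differs from compound 1 by fluoro in place of methoxy on an aromatic carbon. Among the measured compounds shown here, no measured pair shows this change, so its effect in this assay is open; a step no larger than the usual scatter is expected, in either direction. Compound 3 is therefore expected at 1800 nM, within 600 nM to 6000 nM, the expected step being a 1.4-fold higher number from compound 1 to compound 3 (0.13 log units; within the scatter).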

Compound 3, half-maximal inhibitory concentration: > 30000 nM
Compound 3 was reported as a limit; the forecaster's own chance of this, stated with the estimate: 5%; at least 16-fold (1.22 log units) between middle value and limit.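

In this assay the change from 4-methoxyphenyl to 4-fluorophenyl brings an at least 22-fold higher number from compound 1 to compound 3 (1.35 log units; beyond the scatter) and so is far from neutral. With the rest of compound 1 kept, this position clearly matters to inhibition, which compound 1 and compound 2 could not show, as they differ in more than one place. The value of compound 3 is a limit of the assay and not a number: the limit of > 30000 nM in this assay, at which 2 of the 3 values shown sit.

Going by these compounds, whether any other group at this position keeps inhibition stays open, for example a hydroxyl, an amine or the longer ethoxy chain.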